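Aryloxymethyl-imidazolines: pyrrole to methylthiazole at the ortho aryl

A few compounds are considered here, and "the series" means these few. Any claim that something is new, unique, unknown or untested is made for them only; others in the source may bear on it.

Measured in a functional assay for activation of Alpha-1D adrenergic receptor (Homo sapiens), read by calcium flux; on this read-out higher numbers stand for an effect only at larger amounts of compound and lower numbers for an effect already at smaller amounts:
- compound 1 `Cc1ccnc(-c2ccccc2OCC2=NCCN2)c1`: < 100000 nM (a limit)
- compound 2 `Cc1cccc(-c2ccccc2OCC2=NCCN2)n1`: < 100000 nM (a limit)
- compound 3 `c1c[nH]c(-c2ccccc2OCC2=NCCN2)c1`: 6.31 nM

Going by the values given here, compound 3 gives the only real number in this assay. Compound 1 gives only a limit in this assay, < 100000 nM. Compound 2 likewise gives only a limit in this assay, < 100000 nM. Among the compounds with values here, these two limits, (the limit of < 100000 nM in this assay, at which 2 of the 3 values shown sit), allow no step to be measured, so the effect of the aryl group cannot be judged from them.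

Compound 4 `Cc1csc(-c2ccccc2OCC2=NCCN2)n1` differs from compound 3 by 4-methyl-1,3-thiazol-2-yl in place of 1H-pyrrol-2-yl on an aromatic carbon. Within the data shown here, with no measured step to rest on, the step of a 79-fold higher number from compound 3 to compound 4 (1.90 log units; beyond the scatter) is expected to be a loss in potency that goes beyond the scatter. Compound 4 is therefore estimated at 500 nM, within a range of 40 nM to 6000 nM.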

Compound 4, half-maximal effective concentration: < 100000 nM
Compound 4: only a limit was reported (the forecaster's own chance of this, stated with the estimate: 20%); the middle value does not contradict the limit.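

No step from compound 3 to compound 4 can be read in this assay, as compound 4 gives only a limit: the limit of < 100000 nM in this assay, at which 3 of the 4 values shown sit.

The compounds shown leave open how large the change is when 4-methyl-1,3-thiazol-2-yl replaces 1H-pyrrol-2-yl.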